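Amide aryl change from compound 1 to compound 3

The source may report more compounds than this note shows. Statements on the series, on what has been measured and on what is new or still open speak of the compounds shown alone.

Measured so far:
compound 1 `CCN1CCN(c2cc(C)c3cc(NC(=O)c4cccc(Cl)c4)ccc3n2)CC1` — 17800 nM
compound 2 `Cc1cc(NCCN2CCN(C)CC2)nc2ccc(NC(=O)c3ccc(Cl)c(Cl)c3)cc12` — 2690 nM

In a functional assay on SK-BR-3 cells (Homo sapiens) for antiproliferative activity, read by MTT assay, with a stated time of 72 h (on this read-out higher numbers stand for weaker inhibition and lower numbers for stronger inhibition), compound 1 gives 17800 nM, the highest of the two numbers recorded. The nearest neighbour on this read-out is compound 2, which gives 2690 nM, a gap that lies beyond the usual scatter. For the measured compounds named here, no step between measured compounds that differ in a single place is available, so the series offers no direct anchor for the change under consideration.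

Compound 3 `CCN1CCN(c2cc(C)c3cc(NC(=O)c4ccccc4OC)ccc3n2)CC1` differs from compound 1 in one place: 2-methoxyphenyl in place of 3-chlorophenyl on a carbonyl carbon. The group that leaves is 3-chlorophenyl and the group that enters is 2-methoxyphenyl, both carried on a carbonyl carbon whose other neighbour is an amide-type nitrogen; the shared core is otherwise untouched.

Going by the values given here, with no measured pair to guide it, the expected step is a 1.1-fold higher number from compound 1 to compound 3 (0.05 log units; within the scatter), small and without a direction that should stand out beyond the scatter. Compound 3 is estimated at 20000 nM in this assay, with a range from 6000 nM to 60000 nM.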

Compound 3, half-maximal inhibitory concentration: 15700 nM
Beside the measured number, compound 3's estimate is 1.3-fold (0.11 log units) above it; low and high end bracket the measured number.
By their numbers in this assay, from the lowest: compound 2; then compounds 3 and 1 (each within the scatter of the next).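

In this assay, for the compounds shown here, 2-methoxyphenyl in place of 3-chlorophenyl on a carbonyl carbon gives a 1.1-fold lower number from compound 1 to compound 3 (0.05 log units; within the scatter) and is the first single-place step available. On this read-out the two groups cannot be told apart at this place, even though the entering group has one more heavy atom and one hydrogen-bond acceptor where the leaving group has none. Nothing on hand offers an explanation for this flat step or gives a measured property of either group.

Going by these compounds alone, the single step covers only two substituted phenyl groups, so it remains open whether the place tolerates any change or whether a group of another kind on the same carbonyl carbon, such as a phenyl ring bearing an amine or a carboxylic acid, would move the number beyond the scatter. As far as these compounds go, compound 2, at 2690 nM, differs from compound 1 in more than one place, so it remains open which of its differences goes with its number, and a single-place link to either compound 1 or compound 3 would be needed to settle this.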